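From a Methylpyridine to a Carbamoylpyridine Side Group

This account rests on a few compounds, and the source may have more. Where it says the series, first, only, none or still open, it means among the compounds named here.

Compound 1 `Nc1ccccc1-c1cnc(C(=O)CCCCCCc2ccccc2)o1`: 750 nM
Compound 2 `O=C(CCCCCCc1ccccc1)c1ncc(-c2ccc([N+](=O)[O-])cc2)o1`: 50 nM
Compound 3 `Cc1ccnc(-c2cnc(C(=O)CCCCCCc3ccccc3)o2)c1`: 0.6 nM

Three compounds share one core, a long phenyl-capped chain ending in a ketone, and differ only in the aromatic group attached to the five-membered ring. In an assay (Rattus norvegicus) for inhibition of Fatty-acid amide hydrolase 1 (Homo sapiens) (a higher number here means a weaker inhibitor, a lower number a stronger inhibitor), compound 1 gives 750 nM. The change to compound 2 gives a 15-fold lower number from compound 1 to compound 2 (1.18 log units; beyond the scatter). In this assay compound 3 gives 0.6 nM, the lowest number of the three; it stands an 83-fold lower number from compound 2 to compound 3 (1.92 log units; beyond the scatter) and a 1300-fold lower number from compound 1 to compound 3 (3.10 log units; beyond the scatter).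

Compound 4 `NC(=O)c1cccc(-c2cnc(C(=O)CCCCCCc3ccccc3)o2)n1` has not yet been measured. The change from compound 3 is 6-carbamoylpyridin-2-yl in place of 4-methylpyridin-2-yl on an aromatic carbon. The pyridine ring is kept, and only its substituent changes; all three measured steps concern the whole aromatic group, so none bears directly on this exchange. They show only that this part of the molecule moves the number strongly. For compound 4 a modest weakening is expected, a 3.3-fold higher number from compound 3 to compound 4 (0.52 log units; beyond the scatter), possibly within the scatter. Compound 4 is therefore estimated at 2 nM, with a range from 0.3 nM to 15 nM.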

Compound 4, inhibition constant: 1 nM
Compound 4: the middle estimate sits 2.0-fold (0.30 log units) above what was measured; the measured number falls inside the stated range.
By their numbers in this assay, from the lowest: compounds 3 and 4 (each within the scatter of the next); then compound 2; then compound 1.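

In this assay, 6-carbamoylpyridin-2-yl in place of 4-methylpyridin-2-yl gives a 1.7-fold higher number from compound 3 to compound 4 (0.22 log units; within the scatter), so this position accepts a larger group that adds a hydrogen-bond donor, with no change that can be told from the scatter. Both compounds with a pyridine ring stay well apart from those with a benzene ring, as a 50-fold lower number from compound 2 to compound 4 (1.70 log units; beyond the scatter) and a 750-fold lower number from compound 1 to compound 4 (2.88 log units; beyond the scatter) show, and so the low number of compound 3 does not depend on the methyl group being present. No measurement given here explains why these two substituents give numbers so alike.

The two groups differ both in what they are and in where they sit on the pyridine ring, so 6-methylpyridin-2-yl would be needed to tell these two changes apart. From the compounds shown here alone, it also remains open what the unsubstituted pyridin-2-yl group would give, and whether a carboxylic acid or a methyl ester in place of the carbamoyl group would hold the number at this level.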